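From amino to acetamido: what compound 3 may show

The source may hold more compounds than are shown below. What is called first, only, known or untested is meant among the compounds shown, and "the series" means these compounds.

Measured in an ADME assay on HeLa cells (Homo sapiens) for cytotoxicity, read by crystal violet staining, with a stated time of 72 h; a lower number here means that less compound is tolerated, a higher number that more compound is tolerated:

- Compound 1 `CN(C)C(=O)c1cc(CCCOc2ccc(-c3noc(C(F)(F)F)n3)cc2[N+](=O)[O-])on1`: 22500 nM
- Compound 2 `CN(C)C(=O)c1cc(CCCOc2ccc(-c3noc(C(F)(F)F)n3)cc2N)on1`: 90800 nM

Of these two compounds, compound 2 has the higher number, 90800 nM, so more of it is tolerated. The next compound, compound 3 `CC(=O)Nc1cc(-c2noc(C(F)(F)F)n2)ccc1OCCCc1cc(C(=O)N(C)C)no1`, is not yet measured. It differs from compound 2 at a single place: acetyl in place of hydrogen on a nitrogen on an aromatic ring. In short, the change turns amino into acetamido.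

Within the data shown here, only one measured step offers any guidance, and it is a different change: amino in place of nitro on an aromatic carbon. That step, a 4.0-fold higher number from compound 1 to compound 2 (0.61 log units; beyond the scatter), is modest but beyond the scatter. Among the measured compounds shown here, no measured pair shows what adding acetyl does, so the direction remains uncertain. For the measured compounds named here, with only that modest step as a guide, and compound 2 at the top of the two values, a small move to a lower number seems the likeliest outcome in this assay. The expected step is a 1.7-fold lower number from compound 2 to compound 3 (0.22 log units; within the scatter), and it may stay within the usual scatter. For compound 3 the estimated value is 55000 nM, with an expected range from 20000 nM to 180000 nM.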

Compound 3, half-maximal cytotoxic concentration: > 100000 nM
Compound 3 gave a limit, no number (the forecaster's own chance of this, stated with the estimate: 15%); middle value at least 1.8-fold (0.25 log units) from the limit.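

In this assay compound 3 gives a limit of the assay and not a number: the limit of > 100000 nM in this assay, at which 1 of the 3 values shown sits.

Acetyl in place of hydrogen on this nitrogen gives an at least 1.1-fold higher number from compound 2 to compound 3 (0.04 log units; that floor lies within the scatter), so adding acetyl to the amino group shows no sign of lowering the number, something the step from nitro to amino could not show. Acetamido in place of nitro on the aromatic carbon gives an at least 4.4-fold higher number from compound 1 to compound 3 (0.64 log units; beyond the scatter), so among the three groups seen at this place, nitro carries the lowest number in this assay.

On these data alone, how far the true value of compound 3 lies past the limit cannot be read, so whether acetamido really gives a higher number than amino stays open. A longer acyl group such as propanoyl, or a single methyl group on the same nitrogen, would show whether this tolerance extends to other groups at this place, although such compounds could run into the same limit.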